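The compounds below may be only part of what the source reports. "The series", "measured", "known", "first", "only" and "open" are said of these compounds alone.

Among the compounds with values here, in a functional assay on A549 cells (Homo sapiens) for antiproliferative activity, read by MTT assay, with a stated time of 72 h (a higher number here means a weaker inhibitor, a lower number a stronger inhibitor), compound 2, `COc1cc2c(Nc3ccc(C#N)cc3)ncnc2cc1OCCCN1CCC(C)CC1`, gives 32300 nM, the only true number among the three values shown. Compound 1, `COc1cc2c(Nc3ccc(C#N)cc3)ncnc2cc1OCCCN(C)Cc1ccccc1`, reaches only the limit of this assay at > 100000 nM. Compound 3, `COc1cc2c(Nc3ccc(C#N)cc3)ncnc2cc1OCCCN1CCCCC1CCO`, likewise sits at the limit, > 100000 nM. The readable steps are an at least 3.0-fold lower number from compound 1 to compound 2 (0.49 log units; beyond the scatter) and, in the opposite direction, an at least 3.0-fold higher number from compound 2 to compound 3 (0.49 log units; beyond the scatter); each exchanges the group on the saturated chain carbon three bonds from the oxygen on the aromatic ring, and two of the three values rest at the limit of > 100000 nM in this assay, at which 2 of the 3 values shown sit. Compound 4, `CCOC(=O)C1CCN(CCCOc2cc3ncnc(Nc4ccc(C#N)cc4)c3cc2OC)CC1`, differs from compound 2 in ethoxycarbonyl in place of methyl on a saturated ring carbon. The step from compound 2 to compound 3 is the nearest guide: it also alters the substituent on the six-membered non-aromatic ring with one nitrogen, and it moved toward a weaker inhibitor. One therefore expects a higher number in this assay, a 1.9-fold higher number from compound 2 to compound 4 (0.27 log units; within the scatter), and estimates compound 4 at 60000 nM, with a range from 25000 nM to 150000 nM, and a real chance that only a limit is reported.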

Compound 4, half-maximal inhibitory concentration: 89900 nM
Beside the measured number, compound 4's estimate is 1.5-fold (0.18 log units) below it; measured number inside the range.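

In this assay, ethoxycarbonyl in place of methyl on the saturated ring carbon, three ring bonds from the ring nitrogen, gives a 2.8-fold higher number from compound 2 to compound 4 (0.44 log units; beyond the scatter) and so shows that a change at this ring carbon alone, with the chain and the shared core the same, moves the number beyond the scatter. The two other steps give only floors, an at least 1.1-fold lower number from compound 3 to compound 4 (0.04 log units; that floor lies within the scatter) and an at least 1.1-fold lower number from compound 1 to compound 4 (0.04 log units; that floor lies within the scatter) and no order can be read from them: the limit of > 100000 nM in this assay, at which 2 of the 4 values shown sit.

The compounds shown leave open whether the step follows the whole ethoxycarbonyl group or only part of it, as a carboxylic acid, a primary amide or an ethyl group at the same ring carbon could tell. They also leave open whether an amine at this ring carbon would give a lower number than methyl does.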